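This account rests on a few compounds, and the source may have more. Where it says the series, first, only, none or still open, it means among the compounds named here.

Going by the values given here, compound 2 `CC(C)C[C@H](N)c1cc(C(F)(F)F)ccc1N1CCN(C(=O)CCc2c[nH]c3ccccc23)CC1` gives 640 nM in an assay on HEK293 cells for displacement of a labelled ligand from Melanocortin receptor 4 (Homo sapiens) (on this read-out higher numbers stand for weaker inhibition and lower numbers for stronger inhibition), the lowest of the two numbers known so far. Among the compounds with values here, compound 1 `CC(C)C[C@H](N)c1cc(C(F)(F)F)ccc1N1CCN(C(=O)CCc2ccccc2O)CC1` gives 3300 nM in this assay; the single measured step, a 5.2-fold lower number from compound 1 to compound 2 (0.71 log units; beyond the scatter), concerns the aryl group carried by the saturated chain, two bonds along the chain from the carbonyl carbon. Compound 3 `CC(C)C[C@H](N)c1cc(C(F)(F)F)ccc1N1CCN(C(=O)CCc2cn(C)c3ccccc23)CC1` keeps that 1H-indol-3-yl group and differs from compound 2 at its aromatic nitrogen only: methyl in place of hydrogen on an aromatic nitrogen. Within the data shown here, no measured pair alters this nitrogen, so the step from compound 1 to compound 2 bears on it only indirectly: it shows that the 1H-indol-3-yl group is tolerated, and says nothing about the hydrogen it carries. Without a direct precedent, the expectation in this assay is a change within the scatter, in either direction, a 1.3-fold higher number from compound 2 to compound 3 (0.10 log units; within the scatter). Compound 3 is therefore estimated at 800 nM in this assay, with a range from 250 nM to 2500 nM, the width of the range reflecting the missing precedent rather than any measured trend.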

Compound 3, inhibition constant: 3000 nM
Compound 3: the middle estimate sits 3.8-fold (0.57 log units) below what was measured, outside the stated range (above it).
By their numbers in this assay, from the lowest: compound 2; then compounds 3 and 1 (each within the scatter of the next).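

In this assay, the hydrogen on the aromatic nitrogen of the 1H-indol-3-yl group proves to be a sensitive point in the series: methyl in its place gives a 4.7-fold higher number from compound 2 to compound 3 (0.67 log units; beyond the scatter), so a change at this nitrogen alone is enough to move the number beyond the scatter. Going by these compounds alone, the other new step, a 1.1-fold lower number from compound 1 to compound 3 (0.04 log units; within the scatter), stays within the scatter, so 1-methyl-1H-indol-3-yl and 2-hydroxyphenyl on this chain cannot be told apart, and the advantage of compound 2 over compound 1 is seen only with the hydrogen in place on the nitrogen. Nothing available here explains why methyl has this effect at the nitrogen.

Within the data shown here, the series so far has only hydrogen and methyl on this nitrogen, so it remains open whether an ethyl or an acetyl group there would give a number like that of compound 3 or a different one. Going by these compounds, it is also open whether the step seen with methyl would hold on a longer chain between the carbonyl and the 1H-indol-3-yl group.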